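Swapping a Methyl for Fluorines on a Benzamide

The source may report more compounds than this note shows. Statements on the series, on what has been measured and on what is new or still open speak of the compounds shown alone.

Of the compounds shown here, three sharing a sulfonamide-bearing core have been tested in a functional assay on HEK293 cells for agonist activity at probable G-protein coupled receptor 27 (Homo sapiens), read by a luciferase reporter and beta-arrestin recruitment, with a stated time of 10 min; on this read-out higher numbers stand for an effect only at larger amounts of compound and lower numbers for an effect already at smaller amounts. Compound 1 `O=C(Nc1cccc(S(=O)(=O)Nc2ccccc2)c1)c1ccc(Cl)cc1Cl` gives only a limit of the assay, > 100000 nM. Compound 2 `O=C(Nc1ccc(Cl)cc1Cl)c1ccc(S(=O)(=O)Nc2ccccc2)cc1` likewise gives only a limit, > 100000 nM. Compound 3 `Cc1cc(Cl)ccc1C(=O)Nc1ccc(S(=O)(=O)Nc2ccccc2)cc1` is the one compound with a measured number, 912 nM, so it stands alone on the numbers shown. The other two values rest at the limit of > 100000 nM in this assay, at which 2 of the 3 values shown sit. Since compounds 1 and 2 each differ from compound 3 in more than one place, no single-step comparison between measured compounds is available.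

Compound 4 `O=C(Nc1ccc(S(=O)(=O)Nc2ccccc2)cc1)c1cc(F)c(Cl)cc1F` has not yet been measured. It differs from compound 3 in one place: 4-chloro-2,5-difluorophenyl in place of 4-chloro-2-methylphenyl on a carbonyl carbon. Both groups are chlorine-bearing phenyl rings; a methyl leaves and two fluorines enter. For the measured compounds named here, with no measured step to lean on, the expectation for compound 4 is a change of modest size, more likely toward an effect only at larger amounts than toward a stronger one, and possibly within the usual scatter. The estimated step is a 2.2-fold higher number from compound 3 to compound 4 (0.34 log units; beyond the scatter). Compound 4 is expected to give 2000 nM in this assay, with a likely range from 500 nM to 8000 nM.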

Compound 4, half-maximal effective concentration: 141 nM
Estimate against measurement, compound 4: 14-fold (1.15 log units) above; the measured number lies below the stated range.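

In this assay, for the compounds shown here, putting 4-chloro-2,5-difluorophenyl in place of 4-chloro-2-methylphenyl on the carbonyl carbon brings a 6.5-fold lower number from compound 3 to compound 4 (0.81 log units; beyond the scatter), the first step that can be read between two measured compounds differing in one place. It shows that the methyl is not needed for an effect in this pair: with the methyl gone and two fluorines on the ring, the effect appears at smaller amounts of compound, so the groups on this ring can change the read-out well beyond the scatter. Nothing measured here bears on why the step goes in this direction.

The compounds shown leave open which part of the swap carries the step, the loss of the methyl or the arrival of one or the other fluorine, as all of these happen together in this single pair. Also open, on these data alone, is how this position responds to other groups on the ring, such as a methoxy, a nitrile or an amine, and whether the chlorine that both rings carry matters for the effect at all.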